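A few compounds are considered here, and "the series" means these few. Any claim that something is new, unique, unknown or untested is made for them only; others in the source may bear on it.

Working notes on the series.

Going by the values given here, compound 3 `O=S(=O)(NCCCNCc1cccc(Cl)c1)c1cc(C(F)(F)F)cc(C(F)(F)F)c1` gives 2700 nM in a functional assay on HPAC cells (Homo sapiens) for inhibition, read by MTT assay, with a stated time of 72 h (a lower number here means a stronger inhibitor of growth, a higher number a weaker inhibitor of growth), the second highest of the three numbers so far. Compound 2 `O=S(=O)(NCCCCNCc1ccc(Br)cc1)c1cc(C(F)(F)F)cc(C(F)(F)F)c1` gives 2000 nM in the same assay, and the difference a 1.4-fold higher number from compound 2 to compound 3 (0.13 log units; within the scatter) is within the scatter. Compound 1 `O=S(=O)(NCCCNCc1ccccc1Cl)c1cc(C(F)(F)F)cc(C(F)(F)F)c1` gives 10000 nM, and here the step of a 3.7-fold lower number from compound 1 to compound 3 (0.57 log units; beyond the scatter) is beyond the scatter, as is a 5.0-fold lower number from compound 1 to compound 2 (0.70 log units; beyond the scatter).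

Compound 4 `COc1cccc(CNCCCNS(=O)(=O)c2cc(C(F)(F)F)cc(C(F)(F)F)c2)c1` differs from compound 3 by methoxy in place of chloro on an aromatic carbon, meta to a large group, so 3-chlorobenzyl becomes 3-methoxybenzyl.

Among the compounds with values here, none of the measured steps exchanges one ring substituent for a different kind; the steps on record move a halogen around the ring or alter the chain together with the halogen. The steps that come closest are those from compound 1 to compound 3 and from compound 2 to compound 3, both of which keep a halogen on the ring, and they only show that the meta and para arrangements fall within scatter of each other while the ortho arrangement gives a higher number. Within the data shown here, no step informs a chloro-to-methoxy change directly, so the expected step of a 1.1-fold higher number from compound 3 to compound 4 (0.05 log units; within the scatter) is none beyond the scatter, with wide uncertainty. Compound 4 is therefore estimated at 3000 nM in this assay, within 1000 nM to 9000 nM.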

Compound 4, concentration for 50% growth inhibition: 2400 nM
Compound 4: the middle estimate sits 1.3-fold (0.10 log units) above what was measured; the range from low to high includes it.
By their numbers in this assay, from the lowest: compounds 2, 4 and 3 (each within the scatter of the next); then compound 1.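

In this assay, going by these compounds alone, the exchange of chloro for methoxy on the aromatic carbon, meta to a large group, gives a 1.1-fold lower number from compound 3 to compound 4 (0.05 log units; within the scatter), the first step that replaces a ring halogen with a group of a different kind; at this place, the exchange from one heavy atom to two, with one hydrogen-bond acceptor added, leaves the number within the scatter. The halogen is thus not needed on the ring for a number in this range, as a 1.2-fold higher number from compound 2 to compound 4 (0.08 log units; within the scatter) also places the halogen-free compound within the scatter of the 4-bromobenzyl compound, while a 4.2-fold lower number from compound 1 to compound 4 (0.62 log units; beyond the scatter) shows that 3-methoxyphenyl keeps the same separation from 2-chlorophenyl that the 3-chlorophenyl compound showed. No supporting data are available to account for these steps.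

Open, on these data alone, is whether an amine, a carboxylic acid or a nitrile at this place would also stay within the scatter of compound 3 and compound 4. Also open, as far as these compounds go, is whether the chloro-to-methoxy exchange would read the same way on the longer chain of compound 2 or with the ring substituent at the place it occupies in compound 1.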